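Compound 1 to compound 4: replacing the 3-chlorophenoxy group

The source may report more compounds than this note shows. Statements on the series, on what has been measured and on what is new or still open speak of the compounds shown alone.

Measured in an ADME assay on cells (Homo sapiens) for cytotoxicity, read by resazurin assay, with a stated time of 5 days; on this read-out higher numbers stand for lower toxicity in this test and lower numbers for higher toxicity in this test
compound 1 `COc1ccc(-c2nc(COc3cccc(Cl)c3)nc3ccsc23)cn1` gives > 50000 nM (a limit)
compound 2 `O=S(=O)(Cc1nc(-c2ccncc2)c2sccc2n1)c1cccc(Cl)c1` gives > 50000 nM (a limit)
compound 3 `O=S(=O)(Cc1nc(-c2ccc(Cl)nc2)c2sccc2n1)c1cccc(Cl)c1` gives 70000 nM (a number)

Compound 1 stands at a limit and has no number in this assay on which to base a step. Compound 2 also stands at a limit. The next change gives compound 4 `COc1ccc(-c2nc(CC(O)c3cccc(Cl)c3)nc3ccsc23)cn1` and keeps the core of compound 1. It is (3-chlorophenyl)(hydroxy)methyl in place of 3-chlorophenoxy on a saturated chain carbon bound to an aromatic carbon in this series.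

Among the compounds with values here, no measured step covers this change. Within the data shown here, the only step available is a step that the limit leaves unreadable from compound 2 to compound 3 and it concerns 6-chloropyridin-3-yl in place of pyridin-4-yl on an aromatic carbon, so it gives no size to carry over. The expectation therefore rests on the limit of > 50000 nM in this assay, at which 2 of the 3 values shown sit, as the general level of the series. Among the measured compounds shown here, compound 3 with 70000 nM is the only reading that is a number. No step beyond the scatter is expected in this assay and no direction is favoured. The expected step is a step that the limit leaves unreadable from compound 1 to compound 4 as an estimate only. Compound 4 is estimated at 55000 nM with an expected range from 25000 nM to 100000 nM. For compound 4 the expected outcome may well be only a limit.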

Compound 4, half-maximal cytotoxic concentration: 31000 nM
The estimate for compound 4 lay 1.8-fold (0.25 log units) above the measured number, within the range that was stated.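

In this assay, compound 4 gives a number on the core of compound 1, where the 3-chlorophenoxy group left only a limit. Placing (3-chlorophenyl)(hydroxy)methyl in place of 3-chlorophenoxy on a saturated chain carbon bound to an aromatic carbon, a change that adds a hydrogen-bond donor to the count, gives an at least 1.6-fold lower number from compound 1 to compound 4 (0.20 log units; that floor lies within the scatter), so this change is not shown to move the read-out beyond the scatter. The general level of the series is still set by a limit: the limit of > 50000 nM in this assay, at which 2 of the 4 values shown sit.

The full size of this step cannot be read past its floor, and the step from compound 2 to compound 3 cannot be read at all. As far as these compounds go, it also stays open how an amine or a carboxylic acid in place of the hydroxy group would read in this assay.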